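A few compounds are considered here, and "the series" means these few. Any claim that something is new, unique, unknown or untested is made for them only; others in the source may bear on it.

Three compounds that carry the same dihydroxy acid side chain have so far been tested in an in vivo functional assay on the whole organism for inhibition of 3-hydroxy-3-methylglutaryl-coenzyme A reductase (Rattus norvegicus), at a dose of 0.2 mg/kg by the oral route; on this read-out higher numbers stand for a stronger effect at the one dose given and lower numbers for a weaker effect. Compound 1 `Cc1nn(C(C)(C)C)c2nc(C(C)C)c(/C=C/[C@@H](O)C[C@@H](O)CC(=O)O)c(-c3ccc(F)cc3)c12` gives 51.8%. Compound 2 `Cc1cc2c(-c3ccc(F)cc3)c(/C=C/[C@@H](O)C[C@@H](O)CC(=O)O)c(C(C)C)nc2s1` gives -21.5%, a number far lower than that of compound 1, well beyond the scatter of repeated measurements. Compound 3 `CC(C)c1nc2c(c(-c3ccccc3)nn2C)c(-c2ccc(F)cc2)c1/C=C/[C@@H](O)C[C@@H](O)CC(=O)O` gives 37%, which is also lower than compound 1 by more than the scatter. Compound 1 therefore stands highest of the three numbers; its nearest neighbour is compound 3 and its furthest is compound 2.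

Compound 4 `Cc1nn(C)c2nc(C(C)C)c(/C=C/[C@@H](O)C[C@@H](O)CC(=O)O)c(-c3ccc(F)cc3)c12` has not yet been measured in this assay. Compared with compound 1, it carries a smaller group: methyl in place of tert-butyl on an aromatic nitrogen. The tert-butyl leaves and a methyl enters on the aromatic nitrogen of the five-membered ring, next to the ring nitrogen.

Among the measured compounds shown here, no two measured compounds differ in a single place, so no measured step of the same kind exists to lean on, and the three compounds do not show how the size of the group on that nitrogen moves the read-out. The expectation is a moderate step downward, with a range wide enough to include no change beyond the scatter: a number 16.8 percentage points lower from compound 1 to compound 4 (beyond the scatter). Compound 4 is thus estimated to give 35%, between 5% and 60%.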

Compound 4, a percentage reported as inhibition, in the whole organism at one dose (the size of the read-out at that dose, not a potency): 41.1%
For compound 4 the middle estimate is 6.1 percentage points below the measured one, within the range that was stated.
By their numbers in this assay, from the lowest: compound 2; then compounds 3 and 4 (each within the scatter of the next); then compound 1.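

In this assay, replacing tert-butyl with methyl on the aromatic nitrogen gives a number 10.7 percentage points lower from compound 1 to compound 4 (beyond the scatter), so the group at this position does affect the read-out, yet the large tert-butyl is not needed for an effect at this dose, since compound 4 still gives 41.1% in this test. Compound 4 also connects compound 3 to the series through a different change, methyl in place of phenyl on an aromatic carbon, and that change gives a number 4.1 percentage points higher from compound 3 to compound 4 (within the scatter), so at this single dose the two groups cannot be told apart on that carbon. Nothing measured here explains the size of either step.

With only tert-butyl and methyl compared on the nitrogen, two points cannot show whether the read-out follows group size, and an ethyl or cyclohexyl group there could help to settle that. As far as these compounds go, because each number is the size of the effect at one oral dose rather than a potency, it also remains open how these compounds would compare across a range of doses.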